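Fluoro for hydrogen on the fused ring of compound 1

This account rests on a few compounds, and the source may have more. Where it says the series, first, only, none or still open, it means among the compounds named here.

Measured so far:
compound 1 `CCc1cc(Nc2nc(N[C@@H](C)c3ccc(F)cc3)nc3ccccc23)n[nH]1` — 120 nM
compound 2 `CCc1cc(Nc2nc(N[C@@H](C)c3ccc(OC)cc3)nc3ccccc23)n[nH]1` — 290 nM

Both values come from an assay on isolated protein for inhibition of G protein-coupled receptor kinase 6 (Homo sapiens), read by scintillation counting, radiometric assay and 33P incorporation, with a stated time of 80 min, in the presence of a further agent that is not named here; a lower number here means a stronger inhibitor, a higher number a weaker inhibitor. Compound 1 holds the lower of the two numbers; its nearest neighbour is compound 2, and the step of a 2.4-fold higher number from compound 1 to compound 2 (0.38 log units; beyond the scatter) sets the two apart, the change there being methoxy in place of fluoro on an aromatic carbon of the benzylic ring.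

Compound 3 `CCc1cc(Nc2nc(N[C@@H](C)c3ccc(F)cc3)nc3ccc(F)cc23)n[nH]1` differs from compound 1 by fluoro in place of hydrogen on an aromatic carbon, a change that sits on the six-membered aromatic ring of carbon only that is part of the fused system of two rings, not on the ring touched in the step from compound 1 to compound 2. Going by the values given here, no measured step therefore bears on it directly. With only a single fluorine entering and no donor or acceptor added, the expectation for compound 3 in this assay is a step of a 1.1-fold lower number from compound 1 to compound 3 (0.04 log units; within the scatter), within the scatter in either direction. Compound 3 is estimated at 110 nM, with a range of 50 nM to 250 nM.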

Compound 3, half-maximal inhibitory concentration: 160 nM
Beside the measured number, compound 3's estimate is 1.5-fold (0.16 log units) below it; the measured number falls inside the stated range.
By their numbers in this assay, from the lowest: compounds 1, 3 and 2 (each within the scatter of the next, the first and the last beyond it).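

In this assay, going by these compounds alone, the step on the six-membered aromatic ring of carbon only is a 1.3-fold higher number from compound 1 to compound 3 (0.12 log units; within the scatter), the first reading at this part of the fused system, since the earlier pair spoke only to the benzylic ring. Fluoro in place of hydrogen at this carbon, meta to a fused ring and para to a fused ring, leaves compound 1 and compound 3 indistinguishable here, whereas the change on the benzylic ring, a 2.4-fold higher number from compound 1 to compound 2 (0.38 log units; beyond the scatter), lies beyond the scatter. Nothing available accounts for this result.

Still open, going by these compounds, is whether a nitrile, a chloro or an amine at this carbon would also stay within the scatter of compound 1. Also open, on these data alone, is whether fluoro here would give the same reading alongside the methoxy of compound 2.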